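Dropping One Methoxy Group: What Compound 4 Should Show

The source may report more compounds than this note shows. Statements on the series, on what has been measured and on what is new or still open speak of the compounds shown alone.

Compound 1 `CCC1=C(O)c2c(oc(-c3ccccc3C)cc2=O)C(CC)(CC)C1=O`, compound 2 `CCC1=C(O)c2c(oc(-c3ccc(OC)cc3C)cc2=O)C(CC)(CC)C1=O` and compound 3 `CCC1=C(O)c2c(oc(-c3ccc(OC)c(OC)c3OC)cc2=O)C(CC)(CC)C1=O` share a core and differ only on the six-membered aromatic ring of carbon only. In a functional assay on KBVIN cells (Homo sapiens) for antiproliferative activity, read by sulforhodamine B assay, with a stated time of 3 days (on this read-out higher numbers stand for an effect only at larger amounts of compound and lower numbers for an effect already at smaller amounts), compound 1 gives 2.41 uM, compound 2 gives 2.62 uM and compound 3 gives 1.57 uM. From compound 2 to compound 1 the change is hydrogen in place of methoxy on an aromatic carbon, and the step is a 1.1-fold lower number from compound 2 to compound 1 (0.04 log units; within the scatter). The difference between the cores of compound 3 and compound 2 is not broken down here. Compound 4 `CCC1=C(O)c2c(oc(-c3cccc(OC)c3OC)cc2=O)C(CC)(CC)C1=O` arises from compound 3 by the same kind of change, (hydrogen in place of methoxy on an aromatic carbon), but the place is ortho to a methoxy group and meta to a methoxy group rather than meta to a methyl group. Because a 1.1-fold lower number from compound 2 to compound 1 (0.04 log units; within the scatter) lies within the scatter, compound 4 is expected to show a step of a 1.1-fold higher number from compound 3 to compound 4 (0.06 log units; within the scatter). Compound 4 is therefore estimated at 1.8 uM, between 0.9 uM and 3.6 uM.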

Compound 4, concentration for half-maximal effect: 4.02 uM
Compound 4: the middle estimate sits 2.2-fold (0.35 log units) below what was measured; the measured number lies above the stated range.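

Replacing methoxy with hydrogen gave a 2.6-fold higher number from compound 3 to compound 4 (0.41 log units; beyond the scatter) in this assay, so the change did not carry over with the same size from one core to the other. The two steps differ: the same change on two cores in this assay, a 1.1-fold lower number (0.04 log units; within the scatter) from compound 2 to compound 1 and a 2.6-fold higher number (0.41 log units; beyond the scatter) from compound 3 to compound 4, 2.8-fold (0.44 log units) apart, beyond the scatter of two such steps. This shows that, for these two pairs, the size of the step depends on the compound that carries it, but it does not show which feature sets the difference, and two pairs establish no rule for the series.

The compounds shown carry only methyl and methoxy groups on this ring. As far as these compounds go, how the same replacement would behave beside a fluorine, a chlorine or an amine on that ring remains open.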